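The source may report more compounds than this note shows. Statements on the series, on what has been measured and on what is new or still open speak of the compounds shown alone.

Compound 3 `O=C(Nc1c(C(O)(C(F)(F)F)C(F)(F)F)ccc2ccccc12)c1ccc(F)cc1` gives 70 nM in an assay on LtK cells with ATP-sensitive inward rectifier potassium channel 11 (Homo sapiens) as the target (a lower number here means that less compound is needed, a higher number that more compound is needed for the effect), the second highest of the three numbers. Compound 1 `O=C(Nc1c(C(O)(C(F)(F)F)C(F)(F)F)ccc2ccccc12)C1CCC1` gives 45 nM, and the step of a 1.6-fold higher number from compound 1 to compound 3 (0.19 log units; within the scatter) stays within the scatter, whereas compound 2 `O=C(CCc1ccccc1)Nc1c(C(O)(C(F)(F)F)C(F)(F)F)ccc2ccccc12` gives 1750 nM, and the step of a 25-fold lower number from compound 2 to compound 3 (1.40 log units; beyond the scatter) is large. Compound 4 `O=C(Nc1c(C(O)(C(F)(F)F)C(F)(F)F)ccc2ccccc12)c1ccc(Br)cc1` differs from compound 3 by bromo in place of fluoro on an aromatic carbon. Among the measured compounds shown here, no measured step alters a substituent on the six-membered aromatic ring; the steps show only that the (4-fluorophenyl)carbonyl group of compound 3 behaves much like the cyclobutyl of compound 1 and unlike the phenethyl of compound 2. The step expected in this assay for compound 4 is therefore small, a 1.1-fold higher number from compound 3 to compound 4 (0.06 log units; within the scatter). The estimate for compound 4 is 80 nM, between 30 nM and 250 nM.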

Compound 4, half-maximal effective concentration: 47 nM
Beside the measured number, compound 4's estimate is 1.7-fold (0.23 log units) above it; measured number inside the range.
By their numbers in this assay, from the lowest: compounds 1, 4 and 3 (each within the scatter of the next); then compound 2.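

In this assay, bromo in place of fluoro on an aromatic carbon, para to a large group, gives a 1.5-fold lower number from compound 3 to compound 4 (0.17 log units; within the scatter) and so does not separate the two halogens at this position. The (4-bromophenyl)carbonyl group also matches the cyclobutyl with a 1.0-fold higher number from compound 1 to compound 4 (0.02 log units; within the scatter) and stays far from the phenethyl with a 37-fold lower number from compound 2 to compound 4 (1.57 log units; beyond the scatter) as the (4-fluorophenyl)carbonyl group did. No evidence is available to explain these results. From the compounds shown here alone, whether an amine or a carboxylic acid on this aromatic carbon would leave the number unchanged remains open.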